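The compounds below may be only part of what the source reports. "The series", "measured", "known", "first", "only" and "open" are said of these compounds alone.

Measured in a functional assay on MOLT-4 cells (Homo sapiens) for inhibition, read by MTT assay, with a stated time of 4 days; on this read-out higher numbers stand for weaker inhibition and lower numbers for stronger inhibition:

- Compound 1 `COc1cc(NC(C)CCCNC(=O)NNC(=O)NCCCCCO)c2ncccc2c1`: >= 250000 nM, a limit
- Compound 2 `COc1cc(NC(C)CCCNC(=O)NN)c2ncccc2c1`: >= 250000 nM, a limit
- Compound 3 `COc1cc(NC(C)CCCNC(=O)NNC(=O)NC(CO)(CO)CO)c2ncccc2c1`: > 250000 nM, a limit

In this assay compound 3 stands at > 250000 nM, which is a limit and not a number. It has no measured neighbour to be ranked against, since the other values are limits too: the series sits at the limit of > 250000 nM in this assay, at which 1 of the 3 values shown sits, and at the limit of >= 250000 nM in this assay, at which 2 of the 3 values shown sit.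

Compound 4 `COc1cc(NC(C)CCCNC(=O)NNC(=O)NCCCO)c2ncccc2c1` has not yet been measured. It carries 3-hydroxypropyl in place of 2-hydroxy-1,1-bis(hydroxymethyl)ethyl on an amide-type nitrogen. The closest measured change at this place is a step that the two limits leave unreadable from compound 1 to compound 3, where 5-hydroxypentyl gives way to the same group that compound 4 loses. The other two measured changes concern the whole carbamoyl unit: a step that the two limits leave unreadable from compound 1 to compound 2 and a step that the two limits leave unreadable from compound 2 to compound 3. None of these steps has a readable size, so they set no size for the new change. Still, compound 1, with its single hydroxyalkyl chain, gives >= 250000 nM, and this is the main ground for expecting no gain.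

The expected change is a number no higher from compound 3 to compound 4 (the limit leaves the size open), with no shift beyond the scatter anticipated, and a further limit is the likeliest report. For compound 4 the estimated value is 250000 nM, with an expected range from 120000 nM to 300000 nM.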

Compound 4, half-maximal inhibitory concentration: > 250000 nM
Compound 4 gave a limit, no number; the forecaster's own chance of this, stated with the estimate: 80%; the middle value sits exactly at the limit.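

Compound 4, like compound 1, compound 2 and compound 3, gives only a limit and not a number, so no step among these four compounds can be read. The compounds shown leave open whether any of them would give a measured number at all, and so what changing the group on the amide-type nitrogen does to inhibition.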